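The source may hold more compounds than are shown below. What is called first, only, known or untested is meant among the compounds shown, and "the series" means these compounds.

Compound 1 `CN1CCN(c2nc(-c3cccc(O)c3)nc3c2ncn3C)CC1` stands lowest of the three measured compounds in an assay on cells for displacement of a labelled ligand from adenosine receptor A1 (Homo sapiens), read by scintillation counting and radioligand binding, with a stated time of 60 min, tested at 10 uM (on this read-out lower numbers stand for less inhibition and higher numbers for more inhibition at the one concentration tested (going by the name of the read-out)), where compound 1 gives 27.1%. Compound 2 `CN1CCN(c2nc(-c3ccc(Cl)c(C(F)(F)F)c3)nc3[nH]cnc23)CC1` gives 52.4% in this assay, and compound 3 `Cn1cnc2c(N3CCCCC3)nc(-c3cccc(O)c3)nc21` gives 78.5%. Going by the values given here, the only measured step that changes a single place, a number 51.4 percentage points higher from compound 1 to compound 3 (beyond the scatter), concerns the ring attached to the core, not the phenyl group.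

Compound 4 `CN1CCN(c2nc(-c3cccc(Cl)c3)nc3c2ncn3C)CC1` differs from compound 1 in one place: chloro in place of hydroxy on an aromatic carbon. Among the compounds with values here, no measured step alters this hydroxy group, so no step bears directly on the change. Compound 2 also carries a chloro on its phenyl ring, but it differs from compound 1 in more than one place, so its higher value in this assay can only hint that a chloro-bearing phenyl is compatible with moderate inhibition.

With so little to go on, compound 4 is expected to give about 40% in this assay, with a range from 15% to 70%. This corresponds to an expected a number 12.9 percentage points higher from compound 1 to compound 4 (beyond the scatter), a modest and uncertain rise.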

Compound 4, a percentage reported as inhibition, at one concentration (the size of the read-out at that concentration, not a potency): 45.7%
For compound 4 the middle estimate is 5.7 percentage points below the measured one, and the stated range covers the measured number.
By their numbers in this assay, from the lowest: compound 1; then compounds 4 and 2 (each within the scatter of the next); then compound 3.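

In this assay, going by these compounds alone, this is the first change at the phenyl group with everything else held constant, and chloro in place of hydroxy gives a number 18.6 percentage points higher from compound 1 to compound 4 (beyond the scatter). The hydroxy group of compound 1 is therefore not needed for inhibition at the one concentration tested, since 3-chlorophenyl, with no hydrogen-bond donor or acceptor counted for chloro, gives the higher number on the same core. No measurement here explains why the number rises.

On these data alone, it remains open whether other groups on this aromatic carbon, such as fluoro, methoxy or an amine, would give numbers like that of chloro or of hydroxy. As far as these compounds go, it is also open whether chloro in place of hydroxy would raise the number on compound 3, which carries piperidin-1-yl in place of 4-methylpiperazin-1-yl.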